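Thiophene for Furan on the Saturated Ring Carbon

The compounds below may be only part of what the source reports. "The series", "measured", "known", "first", "only" and "open" are said of these compounds alone.

Measured so far:
compound 1 `CC1=C(C(=O)CC(C)C)C(c2ccsc2)NC(=O)N1`: 37%
compound 2 `CC1=C(c2ncc(C)o2)C(c2ccoc2)NC(=O)N1`: 21%

Of the compounds shown here, two have been measured in an assay on membranes from CHO cells for displacement of a labelled ligand from adenosine receptor A1 (Homo sapiens), read by scintillation counting, with a stated time of 60 min, tested at 1 uM; on this read-out higher numbers stand for more inhibition at the one concentration tested (going by the name of the read-out) and lower numbers for less inhibition. Compound 1 gives 37%, while compound 2 gives 21%, the lower of the two numbers, and the gap between them is beyond the usual scatter. The two compounds differ in more than one place, so no single structural change can be tied to that gap, and nothing about the furan-to-thiophene exchange alone can be read from it.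

Compound 3 `CC1=C(c2ncc(C)o2)C(c2ccsc2)NC(=O)N1` has not been measured. It differs from compound 2 in one place: thiophen-3-yl in place of furan-3-yl on a saturated ring carbon. Compound 3 thus carries the same thiophen-3-yl group that compound 1 bears, together with the 5-methyl-1,3-oxazol-2-yl group of compound 2. The step from compound 2 to compound 3 is expected to be small, most likely a modest rise that stays near the scatter, a number 7 percentage points higher from compound 2 to compound 3 (within the scatter). On that basis compound 3 is estimated to reach 28% in this assay, within a range from 12% to 45%.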

Compound 3, a percentage reported as inhibition, at one concentration (the size of the read-out at that concentration, not a potency): 34%
Estimate against measurement, compound 3: 6 percentage points below, within the range that was stated.
By their numbers in this assay, from the lowest: compound 2; then compounds 3 and 1 (each within the scatter of the next).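

In this assay the exchange of furan-3-yl for thiophen-3-yl on a saturated ring carbon gives a number 13 percentage points higher from compound 2 to compound 3 (beyond the scatter) with the 5-methyl-1,3-oxazol-2-yl group held fixed, so this position responds to sulfur in place of oxygen in the ring even though the counts of heavy atoms, donors and acceptors are the same. With thiophen-3-yl held fixed, 5-methyl-1,3-oxazol-2-yl in place of isobutylcarbonyl on a double-bonded ring carbon gives a number 3 percentage points lower from compound 1 to compound 3 (within the scatter) and the two groups at that place cannot be told apart on this read-out. Nothing available explains either step.

The compounds shown leave open whether the gain from thiophen-3-yl also appears alongside isobutylcarbonyl, since the only furan-3-yl compound here carries the 5-methyl-1,3-oxazol-2-yl group. They also leave open how the saturated ring carbon would respond to a phenyl ring or a longer chain, and how the double-bonded ring carbon would respond to an amine or a carboxylic acid, as only two groups are shown at each place and each was read at one concentration.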